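Cyclobutyl for Ethyl on the Sulfonyl Chain

The source may report more compounds than this note shows. Statements on the series, on what has been measured and on what is new or still open speak of the compounds shown alone.

Compound 1 `CCCS(=O)(=O)[C@H]1CC[C@@](CNC(=O)c2ccc(Cl)cc2Cl)(CC2CC2)CC1`: 1630 nM in an assay on isolated protein for inhibition of sodium- and chloride-dependent glycine transporter 1 (Homo sapiens), with a stated time of 15 min; on this read-out lower numbers stand for stronger inhibition and higher numbers for weaker inhibition
Compound 2 `O=C(NC[C@]1(CC2CC2)CC[C@H](S(=O)(=O)CC2CC2)CC1)c1ccc(Cl)cc1Cl`: 29 nM in this assay
Compound 3 `CCCS(=O)(=O)[C@H]1CC[C@](CNC(=O)c2ccc(Cl)cc2Cl)(CC2CC2)CC1`: 36.9 nM in this assay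

Compound 3 stands second highest of the three numbers in this assay. The nearest step is a 1.3-fold higher number from compound 2 to compound 3 (0.10 log units; within the scatter); the furthest is a 44-fold lower number from compound 1 to compound 3 (1.65 log units; beyond the scatter), a step that rests on (the fact that compounds 1 and 3 differ only in the configuration as drawn). Compound 4 `O=C(NC[C@]1(CC2CC2)CC[C@H](S(=O)(=O)CC2CCC2)CC1)c1ccc(Cl)cc1Cl` differs from compound 3 by cyclobutyl in place of ethyl on a saturated chain carbon bound to a sulfonyl sulfur. The measured step that bears on this change is the one between cyclopropyl and ethyl at the same place, which stayed within the scatter. A further ring at this position is therefore expected to bring no step beyond the scatter in this assay, a 1.2-fold lower number from compound 3 to compound 4 (0.06 log units; within the scatter). Compound 4 is estimated at 32 nM, between 12 nM and 90 nM.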

Compound 4, half-maximal inhibitory concentration: 629 nM
Beside the measured number, compound 4's estimate is 20-fold (1.29 log units) below it, outside the stated range (above it).
By their numbers in this assay, from the lowest: compounds 2 and 3 (each within the scatter of the next); then compound 4; then compound 1.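

In this assay this position proves far less tolerant than the step between cyclopropyl and ethyl suggested: cyclobutyl brings a 17-fold higher number from compound 3 to compound 4 (1.23 log units; beyond the scatter) and, set against cyclopropyl, a 22-fold higher number from compound 2 to compound 4 (1.34 log units; beyond the scatter) in the same assay. Among the compounds shown, the place on a saturated chain carbon bound to a sulfonyl sulfur therefore does not treat all carbon groups alike. Nothing measured here accounts for this loss. The compounds shown leave open whether the step follows the four-membered ring itself or simply the larger carbon group. A butyl chain or a cyclopentyl ring at this place would bear on that question.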